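Replacing the 3-chlorophenyl group of compound 2

The source may report more compounds than this note shows. Statements on the series, on what has been measured and on what is new or still open speak of the compounds shown alone.

Two related compounds have so far been tested in a functional assay on MCF7 cells (Homo sapiens) for cytotoxicity, read by CellTiter-Glo, with a stated time of 5 days; on this read-out lower numbers stand for stronger inhibition and higher numbers for weaker inhibition. Compound 1 (`CC/C(=C(/c1ccc(/C=C/C(=O)O)cc1)c1ccc2[nH]c(=O)oc2c1)c1ccccc1`) gives 56 nM, and compound 2 (`CC/C(=C(/c1ccc(/C=C/C(=O)O)cc1)c1ccc2[nH]ncc2c1)c1cccc(Cl)c1`) gives 12 nM. Compound 2 therefore holds the lower of the two numbers, and the gap lies beyond the usual scatter, so it shows the stronger inhibition of this pair. The two compounds differ in more than one place, so their gap cannot be pinned on any single group.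

Compound 3 (`CC/C(=C(/c1ccc(/C=C/C(=O)O)cc1)c1ccc2[nH]ncc2c1)c1ccc(C#N)cc1`) has not yet been measured. It keeps the core of compound 2 but carries 4-cyanophenyl in place of 3-chlorophenyl on a double-bonded chain carbon bound to a double-bonded chain carbon and a saturated chain carbon. Within the data shown here, no measured pair shows what this swap does, so the expectation rests on compound 2 alone, at 12 nM. In this assay a slightly higher number, meaning slightly weaker inhibition, is expected, a 1.7-fold higher number from compound 2 to compound 3 (0.22 log units; within the scatter), and this would stay within the usual scatter. Compound 3 is estimated at 20 nM, with an expected range of 6 nM to 70 nM.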

Compound 3, half-maximal inhibitory concentration: 47 nM
Estimate against measurement, compound 3: 2.4-fold (0.37 log units) below; the range from low to high includes it.
By their numbers in this assay, from the lowest: compound 2; then compounds 3 and 1 (each within the scatter of the next).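

In this assay, putting 4-cyanophenyl in place of 3-chlorophenyl on a double-bonded chain carbon bound to a double-bonded chain carbon and a saturated chain carbon gives a 3.9-fold higher number from compound 2 to compound 3 (0.59 log units; beyond the scatter), which means weaker inhibition. Among these compounds, this is the first comparison here that changes only one place, so, unlike the earlier pair, it ties a difference in inhibition to a single group and shows that the read-out is sensitive to which substituted phenyl ring sits at this position. Nothing available here explains the size or direction of this step.

The swap changes both the substituent, chlorine to nitrile, and the number in the group's name, 3 to 4, so these compounds cannot show which of the two matters; 3-cyanophenyl and 4-chlorophenyl on the same core would separate them. Also open, from the compounds shown here alone, are how unsubstituted phenyl or a non-aromatic group such as cyclohexyl would behave at this position on that core, and whether the same swap would have a similar effect on the core of compound 1.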